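Notes on the step from compound 3 to compound 4

The source may report more compounds than this note shows. Statements on the series, on what has been measured and on what is new or still open speak of the compounds shown alone.

Measured in a functional assay on HepG2 cells (Homo sapiens) for cytotoxicity, read by MTT assay; a higher number here means a weaker inhibitor, a lower number a stronger inhibitor:
compound 1 `COc1ccc(/C=C/C(=O)c2ccc(OC)c3c2OC(C)(C)C=C3)cc1OCCCN(C)C` gives 5550 nM
compound 2 `CCC(=O)Oc1cc(/C=C/C(=O)c2ccc(OC)c3c2OC(C)(C)C=C3)ccc1OC` gives 90 nM
compound 3 `CCCCC(=O)Oc1cc(/C=C/C(=O)c2ccc(OC)c3c2OC(C)(C)C=C3)ccc1OC` gives 100 nM

Compound 3 cannot be told apart from its nearest neighbour (a 1.1-fold higher number from compound 2 to compound 3 (0.05 log units; within the scatter)), a step within the scatter. It lies far from the remaining measured compound (a 56-fold lower number from compound 1 to compound 3 (1.74 log units; beyond the scatter)).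

Compound 4 `COc1cccc(C(=O)Oc2cc(/C=C/C(=O)c3ccc(OC)c4c3OC(C)(C)C=C4)ccc2OC)c1` has 3-methoxyphenyl in place of butyl on a carbonyl carbon. Going by the values given here, only one measured step changes the group on this carbonyl (a 1.1-fold higher number from compound 2 to compound 3 (0.05 log units; within the scatter)), and it produced no change beyond the scatter. Among the compounds with values here, that step only extends a saturated chain, however, and no measured compound has a ring at this place, so the present data give no direct reading of the new group. The two large steps (a 62-fold lower number from compound 1 to compound 2 (1.79 log units; beyond the scatter)) and (a 56-fold lower number from compound 1 to compound 3 (1.74 log units; beyond the scatter)) replace 3-(dimethylamino)propyl on an oxygen on an aromatic ring. They show how much the group on that oxygen can matter, which argues for a wide range, but they give no direction for this change.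

No step beyond the scatter is therefore expected in this assay. The expected step is small (a 1.3-fold higher number from compound 3 to compound 4 (0.11 log units; within the scatter)). The estimate for compound 4 is (130 nM), with an expected range from (40 nM) to (450 nM).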

Compound 4, half-maximal inhibitory concentration: 870 nM
Compound 4: middle estimate off by 6.7-fold (0.83 log units), on the low side, and the stated range ends below it.
By their numbers in this assay, from the lowest: compounds 2 and 3 (each within the scatter of the next); then compound 4; then compound 1.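

In this assay, the group on this carbonyl carbon does affect the read-out: 3-methoxyphenyl in place of butyl gives (an 8.7-fold higher number from compound 3 to compound 4 (0.94 log units; beyond the scatter)), and 3-methoxyphenyl in place of ethyl gives a step of similar size (a 9.7-fold higher number from compound 2 to compound 4 (0.99 log units; beyond the scatter)), whereas the change between the two saturated chains stays small (a 1.1-fold higher number from compound 2 to compound 3 (0.05 log units; within the scatter)). Tolerance at this place therefore covers ethyl and butyl but does not carry over to this aromatic group, so the chain data alone do not describe the position. Going by these compounds alone, the (3-methoxyphenyl)carbonyl group on the oxygen still retains part of the advantage over 3-(dimethylamino)propyl (a 6.4-fold lower number from compound 1 to compound 4 (0.80 log units; beyond the scatter)), although this step is smaller than the one to the propanoyl group (a 62-fold lower number from compound 1 to compound 2 (1.79 log units; beyond the scatter)), and no information at hand accounts for the loss at this position.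

Still open, from the compounds shown here alone, is whether the ring itself or its methoxy group goes with the higher number, a question that plain phenyl and cyclohexyl on the same carbonyl carbon would help to separate. Going by these compounds, it is also open whether a chain longer than butyl, or one ending in an amine, would stay close to compound 2 and compound 3.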